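A few compounds are considered here, and "the series" means these few. Any claim that something is new, unique, unknown or untested is made for them only; others in the source may bear on it.

Measured compounds and their values:

compound 1, `CO[C@H]1O[C@H](COc2ccccc2C(C)C)[C@@H](O)[C@H](O)[C@H]1Oc1ccc(OC2CCCCC2)cc1`: 33000 nM
compound 2, `CO[C@@H]1O[C@H](COc2ccccc2C(C)C)[C@@H](O)[C@H](O)[C@H]1Oc1ccc(OC2CCCCC2)cc1`: 41000 nM

Going by the values given here, compound 1 stands with the lowest of the two numbers in a functional assay on A549 cells (Homo sapiens) for cytotoxicity, read by MTT assay, with a stated time of 48 h; a higher number here means that more compound is needed for the effect, a lower number that less compound is needed; its only neighbour is compound 2, and the difference between them is a 1.2-fold higher number from compound 1 to compound 2 (0.09 log units; within the scatter), a step that rests on nothing more than the fact that compounds 1 and 2 differ only in the configuration as drawn. Compound 3, `CO[C@H]1O[C@H](COc2cccc(C(C)C)c2)[C@@H](O)[C@H](O)[C@H]1Oc1ccc(OC2CCCCC2)cc1`, has not yet been measured. It differs from compound 1 by 3-isopropylphenyl in place of 2-isopropylphenyl on an oxygen on a saturated carbon. Among the compounds with values here, none of the measured steps touches this part of the molecule: the one step that has been measured, from compound 1 to compound 2, alters only the configuration at a saturated ring carbon and stays within the scatter. Within the data shown here, there is thus no measured step that bears on moving the isopropyl group on the phenyl ring, and no direction can be read from the data. The step expected from compound 1 to compound 3 is a 1.1-fold higher number from compound 1 to compound 3 (0.03 log units; within the scatter), a change within the scatter. Compound 3 is therefore estimated to give 35000 nM in this assay, with an expected range from 12000 nM to 100000 nM.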

Compound 3, half-maximal effective concentration: 30000 nM
Beside the measured number, compound 3's estimate is 1.2-fold (0.07 log units) above it; the measured number falls inside the stated range.
By their numbers in this assay, from the lowest: compounds 3, 1 and 2 (each within the scatter of the next).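

In this assay, going by these compounds alone, putting 3-isopropylphenyl in place of 2-isopropylphenyl on an oxygen on a saturated carbon gives a 1.1-fold lower number from compound 1 to compound 3 (0.04 log units; within the scatter), the first measured step at this part of the molecule. The earlier pair spoke only to the configuration at a saturated ring carbon, whereas this result shows that, on the core of compound 1, the two isopropylphenyl groups cannot be told apart in this assay, so this change to the isopropyl group's attachment on the phenyl ring gives no handle on the number. Nothing at hand bears on why this step is as it is.

From the compounds shown here alone, it remains open whether a larger step would appear at this place if the isopropyl group gave way to another group, such as an amine, a carboxylic acid or a longer chain. Going by these compounds, it is equally open whether the change from 2-isopropylphenyl to 3-isopropylphenyl would give a similar result with the configuration drawn in compound 2, or in any cell line other than the one tested here.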